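A few compounds are considered here, and "the series" means these few. Any claim that something is new, unique, unknown or untested is made for them only; others in the source may bear on it.

In a functional assay on L6 cells (Rattus norvegicus) for inhibition, read by scintillation counting, with a stated time of 3 h (a lower number here means a stronger inhibitor, a higher number a weaker inhibitor), three amides on a shared core have been read. Compound 1 (`Cc1ccccc1CNC(=O)c1nc(-c2ccc(F)cc2)n(CC[C@@H](O)C[C@@H](O)CC(=O)O)c1C1CC1`) gives 4850 nM as its half-maximal inhibitory concentration, compound 2 (`Cc1ccc(CNC(=O)c2nc(-c3ccc(F)cc3)n(CC[C@@H](O)C[C@@H](O)CC(=O)O)c2C2CC2)cc1`) gives 178 nM on the same read-out, and compound 3 (`O=C(O)C[C@H](O)C[C@H](O)CCn1c(-c2ccc(F)cc2)nc(C(=O)NCc2cccc(F)c2)c1C1CC1`) gives 444 nM and so stands second highest of the three. Its nearest step is modest (a 2.5-fold higher number from compound 2 to compound 3 (0.40 log units; beyond the scatter)) and its furthest is large (an 11-fold lower number from compound 1 to compound 3 (1.04 log units; beyond the scatter)). The change to compound 4 (`CN(C)S(=O)(=O)c1ccc(CNC(=O)c2nc(-c3ccc(F)cc3)n(CC[C@@H](O)C[C@@H](O)CC(=O)O)c2C2CC2)cc1`) is 4-(dimethylsulfamoyl)phenyl in place of 3-fluorophenyl on a saturated chain carbon bound to an amide-type nitrogen and puts 4-(dimethylsulfamoyl)phenyl in place of 3-fluorophenyl on a saturated chain carbon bound to an amide-type nitrogen. Among the measured compounds shown here, all the measured steps fall at this same place, and the largest (a 27-fold lower number from compound 1 to compound 2 (1.44 log units; beyond the scatter)) shows how far the number can move there. For the measured compounds named here, none of the measured compounds carries the entering group, so the direction is poorly fixed. A moderate move to a higher number in this assay is expected, held loosely. The estimated step is a 2.3-fold higher number from compound 3 to compound 4 (0.35 log units; beyond the scatter) and its uncertainty is wide. For compound 4 the expected value is 1000 nM with an estimated range from 200 nM to 5000 nM as its likely span.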

Compound 4, half-maximal inhibitory concentration: > 100000 nM
Compound 4 ended at the assay's limit; the forecaster's own chance of this, stated with the estimate: 5%; middle value at least 100-fold (2.00 log units) away from the limit.
By their numbers in this assay, from the lowest: compound 2; then compound 3; then compound 1. At a limit, above all of these: compound 4.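

In this assay compound 4 gives > 100000 nM, which is a limit of the assay and not a number: the limit of > 100000 nM in this assay, at which 1 of the 4 values shown sits. The earlier compounds shown here showed the number moving widely at this place while staying measurable, whereas here there is an at least 220-fold higher number from compound 3 to compound 4 (2.35 log units; beyond the scatter), and even the highest earlier compound is passed, with an at least 20-fold higher number from compound 1 to compound 4 (1.31 log units; beyond the scatter). Among the compounds shown here, the tightest comparison is an at least 560-fold higher number from compound 2 to compound 4 (2.74 log units; beyond the scatter), where dimethylsulfamoyl in place of methyl on an aromatic carbon is the only change, so that single swap is enough to carry a measurable compound to the limit.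

The compounds shown leave open whether this loss belongs to the sulfonyl unit or to its two methyl groups on nitrogen. A primary sulfonamide, a methylsulfonyl group or a simple methoxy group in the same place would separate these readings.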